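Methylating One Hydroxy Group of a Benzyloxyphenyl Imine

The source may report more compounds than this note shows. Statements on the series, on what has been measured and on what is new or still open speak of the compounds shown alone.

For the measured compounds named here, compound 1 `Oc1ccc(O)c(/C=N/c2ccc(OCc3ccccc3)cc2)c1` gives the lowest of the two numbers so far in an assay on isolated protein for inhibition of Amine oxidase [flavin-containing] B (Homo sapiens), read by fluorescence and Amplex Red, with stated times of 15 min and 20 min (a lower number here means a stronger inhibitor, a higher number a weaker inhibitor), with 1230 nM. Its nearest neighbour, compound 2 `Cc1ccc(/C=N/c2ccc(OCc3ccccc3)cc2)c(O)c1`, gives 24400 nM, and the shift a 20-fold higher number from compound 1 to compound 2 (1.30 log units; beyond the scatter) is large. Compound 3 `COc1ccc(O)c(/C=N/c2ccc(OCc3ccccc3)cc2)c1` differs from compound 1 by methyl in place of hydrogen on an oxygen on an aromatic ring, which caps one hydroxy as methoxy. Going by the values given here, the single measured step also removes a hydroxy from that ring, so it bears on this change, though it brings in a methyl group as well. A smaller loss in this assay is therefore expected for compound 3, with a 3.3-fold higher number from compound 1 to compound 3 (0.51 log units; beyond the scatter). Compound 3 is estimated at 4000 nM, within 1500 nM to 12000 nM.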

Compound 3, half-maximal inhibitory concentration: 10700 nM
Compound 3: middle estimate off by 2.7-fold (0.43 log units), on the low side, and the stated range covers the measured number.
By their numbers in this assay, from the lowest: compound 1; then compound 3; then compound 2.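

In this assay the change is confined to one hydrogen on an oxygen on an aromatic ring, and capping that hydroxy as methoxy gives an 8.7-fold higher number from compound 1 to compound 3 (0.94 log units; beyond the scatter). Unlike the earlier step, this one brings no methyl onto a ring carbon, so the free hydroxy itself counts in this assay, although the step is printed as modest. Nothing shown gives a reason for this loss. The compounds shown leave open whether an amine in place of this hydroxy would restore the lower number, and how a longer ethoxy chain on the oxygen would read.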